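Swapping a Halogen on the Core of Compound 2

The compounds below may be only part of what the source reports. "The series", "measured", "known", "first", "only" and "open" are said of these compounds alone.

Of the compounds shown here, two have been measured in a functional assay on MCF7 cells (Homo sapiens) for antiproliferative activity; on this read-out higher numbers stand for weaker inhibition and lower numbers for stronger inhibition. Compound 1 `O=c1cc[nH]c(=O)n1C1CN(S(=O)(=O)c2ccccc2[N+](=O)[O-])c2ccccc2CO1` gives 50900 nM. Compound 2 `Clc1ncnc2ncn(C3COc4ccccc4CO3)c12` gives 1250 nM, the lower of the two numbers, with the gap to compound 1 lying well beyond the scatter. Compound 3 `Ic1ncnc2ncn(C3COc4ccccc4CO3)c12` keeps the shared core and differs from compound 2 by iodo in place of chloro on an aromatic carbon. Among the measured compounds shown here, no measured pair shows what such a halogen swap does here, so in this assay the step is expected to stay within the scatter, in either direction. Compound 3 is therefore estimated at 1000 nM, between 300 nM and 3500 nM, a step of a 1.3-fold lower number from compound 2 to compound 3 (0.10 log units; within the scatter).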

Compound 3, half-maximal inhibitory concentration: 1250 nM
Compound 3: middle estimate off by 1.3-fold (0.10 log units), on the low side; the measured number falls inside the stated range.
By their numbers in this assay, from the lowest: compounds 2 and 3 (each within the scatter of the next); then compound 1.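

In this assay, iodo in place of chloro on this aromatic carbon, next to the ring nitrogen, gives no change at the digits printed from compound 2 to compound 3 (within the scatter). Among the compounds shown here, this is the first measured pair with a single difference, and it shows that these two halogens read alike at this position on the shared core. Nothing on hand bears on why they read alike. On these data alone, it remains open whether an amine or a methoxy group on this same carbon would move the number beyond the scatter. The same question holds for bromo or fluoro.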